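The compounds below may be only part of what the source reports. "The series", "measured", "known", "first", "only" and "open" are said of these compounds alone.

Compound 3 `O=C(Nc1ccc(Sc2nc3ccccc3s2)cc1)c1cccc(Br)c1` gives only a limit in an assay for inhibition of HSP60/HSP10 (Homo sapiens), with a stated time of 60 min (a lower number here means a stronger inhibitor, a higher number a weaker inhibitor), > 100000 nM. Compound 1 `COc1ccccc1C(=O)Nc1ccc(Sc2nc3ccccc3s2)cc1` likewise sits at a limit, > 100000 nM. Within the data shown here, compound 2 `O=C(Nc1ccc(Sc2nc3ccccc3s2)cc1)c1cccc(Br)c1O` is the one member with a number, 26000 nM. Two of the three values sit at the limit of > 100000 nM in this assay, at which 2 of the 3 values shown sit. Compound 4 `O=C(Nc1ccc(Sc2nc3ccccc3s2)cc1)c1cc(Br)ccc1O` differs from compound 3 by hydroxy in place of hydrogen on an aromatic carbon. The step that bears on this is the removal of the same kind of group, an at least 3.8-fold higher number from compound 2 to compound 3 (0.58 log units; beyond the scatter), which moved the number up; compound 4 carries its bromo as 5-bromo-2-hydroxyphenyl where compound 2 carries 3-bromo-2-hydroxyphenyl, so the reversal need not be of equal size. The step expected is an at least 2.5-fold lower number from compound 3 to compound 4 (0.39 log units; beyond the scatter), downward, though a limit remains possible. Compound 4 is estimated at 40000 nM, between 15000 nM and 150000 nM.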

Compound 4, half-maximal inhibitory concentration: > 100000 nM
Compound 4: a limit, no number; the forecaster's own chance of this, stated with the estimate: 40%; at least 2.5-fold (0.39 log units) between middle value and limit.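

In this assay, 5-bromo-2-hydroxyphenyl in place of 3-bromo-2-hydroxyphenyl gives an at least 3.8-fold higher number from compound 2 to compound 4 (0.58 log units; beyond the scatter). Hydroxy alone is therefore not enough for a measurable number: compound 4 has it and stays at a limit, and among the compounds shown only compound 2, with its 3-bromo-2-hydroxyphenyl group, escapes the limit. The steps from compound 1 and compound 3 to compound 4 cannot be read, since both ends are limits: the limit of > 100000 nM in this assay, at which 3 of the 4 values shown sit.

Going by these compounds, whether an amine or a carboxylic acid in place of the hydroxy of compound 2 would retain a number stays open. So does the true value of compound 4 beyond its limit.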